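A few compounds are considered here, and "the series" means these few. Any claim that something is new, unique, unknown or untested is made for them only; others in the source may bear on it.

Compound 3 `COc1ccc(/C=N/NC(=O)c2ccc(-c3nc4ccccc4s3)cc2)cc1` is one of three hydrazones built on a shared core that carry different aryl groups on the carbon with a double bond to nitrogen. In an assay on isolated protein for inhibition of Maltase-glucoamylase (Homo sapiens), with a stated time of 15 min (on this read-out higher numbers stand for weaker inhibition and lower numbers for stronger inhibition), compound 3 gives 18300 nM. Compound 1 `O=C(N/N=C/c1cccs1)c1ccc(-c2nc3ccccc3s2)cc1` gives 8480 nM in this assay, and compound 2 `O=C(N/N=C/c1ccc(F)c(Br)c1)c1ccc(-c2nc3ccccc3s2)cc1` gives 28000 nM. Compound 3 thus sits second highest of the three numbers: there is a 2.2-fold higher number from compound 1 to compound 3 (0.33 log units; beyond the scatter), while there is a 1.5-fold lower number from compound 2 to compound 3 (0.18 log units; within the scatter), so compound 2 and compound 3 cannot be told apart on this read-out. The remaining step, a 3.3-fold higher number from compound 1 to compound 2 (0.52 log units; beyond the scatter), is the largest seen so far.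

Compound 4 `COc1cc(/C=N/NC(=O)c2ccc(-c3nc4ccccc4s3)cc2)ccc1O` differs from compound 3 in one place: 4-hydroxy-3-methoxyphenyl in place of 4-methoxyphenyl on a carbon with a double bond to nitrogen. All three measured steps bear on this change only loosely, since each swaps the whole aryl group on that carbon rather than adding a hydroxy group to it. Those steps ranged from within the scatter to modest, and none of them involved a hydrogen-bond donor entering. Compound 4 is therefore expected to stay close to compound 3, with a step of a 1.2-fold lower number from compound 3 to compound 4 (0.09 log units; within the scatter) in this assay that may well fall within the scatter. The estimate for compound 4 is 15000 nM, ranging from 6000 nM to 40000 nM.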

Compound 4, half-maximal inhibitory concentration: 53300 nM
For compound 4 the middle estimate is 3.6-fold (0.55 log units) below the measured one, and the stated range ends below it.
By their numbers in this assay, from the lowest: compound 1; then compounds 3, 2 and 4 (each within the scatter of the next, the first and the last beyond it).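

Among these compounds, replacing 4-methoxyphenyl with 4-hydroxy-3-methoxyphenyl on the carbon with a double bond to nitrogen, a change that brings in a hydrogen-bond donor, gives a 2.9-fold higher number from compound 3 to compound 4 (0.46 log units; beyond the scatter) in this assay, the first step beyond the scatter between two substituted phenyl groups at this position. The step of a 1.9-fold higher number from compound 2 to compound 4 (0.28 log units; within the scatter) does not separate these two compounds, whereas a 6.3-fold higher number from compound 1 to compound 4 (0.80 log units; beyond the scatter) is the widest step in the set, and thiophen-2-yl keeps the lowest number against all three phenyl groups. No measurement is at hand that explains why this change moves the number in this direction.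

The compounds shown leave open whether the hydroxy group, the methoxy group or the two together carry the step, a question that 4-hydroxyphenyl and 3,4-dimethoxyphenyl groups at the same carbon would help to settle. They also leave open how an amine or a carboxylic acid on the phenyl ring would read here, and whether another five-membered ring, such as furan-2-yl, would stay as low as thiophen-2-yl.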